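The compounds below may be only part of what the source reports. "The series", "measured", "known", "first", "only" and "open" are said of these compounds alone.

Working notes on the series. Within the data shown here, compound 1 `CC[C@H](C)[C@H](NC(=O)c1cccc(Cn2ccnc2)c1)C(=O)Nc1nccs1` is the only member with a number: in an assay on HEK293 cells for displacement of a labelled ligand from Type-2 angiotensin II receptor (Homo sapiens) (a higher number here means a weaker inhibitor, a lower number a stronger inhibitor), compound 1 gives 42000 nM, a weak result. Compound 2 `CCCCNC(=O)[C@@H](NC(=O)c1cccc(Cn2ccnc2)c1)[C@@H](C)CC` carries a butylamide in place of the thiazolylamide of compound 1, and in this assay compound 2 gives "not determined" (no result reported), so no result was reported for it. Among the measured compounds shown here, compound 3 `CC[C@H](C)[C@H](NC(=O)c1cccc(Cn2ccnc2)c1)c1nn[nH]n1` replaces that part with a tetrazole, and in this assay compound 3 gives "not determined" (no result reported); it therefore stands nowhere on the measured scale, and no step between measured compounds exists anywhere in the set.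

Compound 4 `CCCCS(=O)(=O)NC(=O)[C@@H](NC(=O)c1cccc(Cn2ccnc2)c1)[C@@H](C)CC` is the next entry to be measured. Relative to compound 3 the change is (butylsulfonyl)carbamoyl in place of 2H-tetrazol-5-yl on a saturated chain carbon bound to an amide-type nitrogen and a saturated chain carbon. For the measured compounds named here, with compound 3 undetermined, no step to compound 4 can be sized or given a direction; the only anchor is compound 1, whose 42000 nM sets the series as weak. Compound 4 is expected in this assay to give about 20000 nM, estimated to lie between 3000 nM and 100000 nM, because compound 1 at 42000 nM is the sole measured reference and the change is unanchored.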

Compound 4, inhibition constant: 9900 nM
For compound 4 the middle estimate is 2.0-fold (0.31 log units) above the measured one; the range from low to high includes it.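

In this assay, butylsulfonyl in place of 1,3-thiazol-2-yl on an amide-type nitrogen gives a 4.2-fold lower number from compound 1 to compound 4 (0.63 log units; beyond the scatter). Among these compounds, this is the first readable step: it lies beyond the usual scatter, though it is modest, and it shows that the number responds to a change at this amide-type nitrogen. The steps to compound 4 from compound 2 and compound 3 cannot be read, and nothing at hand accounts for the step from the thiazolyl to the butylsulfonyl group.

The compounds shown leave open whether the sulfonyl group or the butyl chain carries the step. They also leave open how a phenylsulfonyl group, a longer chain on the sulfonyl group or a carboxylic acid in place of the (butylsulfonyl)carbamoyl group would read in this assay.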